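The compounds below may be only part of what the source reports. "The series", "measured", "known", "first", "only" and "open" are said of these compounds alone.

Compound 1, `CCCc1c[nH]c2ccc(F)cc12`: in an assay on isolated protein for inhibition of Myeloperoxidase (Homo sapiens), read by ELISA, with a stated time of 5 min (on this read-out higher numbers stand for weaker inhibition and lower numbers for stronger inhibition), compound 1 gives > 100 nM, which is a limit of the assay rather than a number.
Compound 2, `ONCCCc1c[nH]c2ccc(F)cc12`: in this assay compound 2 gives 21 nM.

Compound 2 holds the only number shown in this assay; the other value shown is the limit described in the limit of > 100 nM in this assay, at which 1 of the 2 values shown sits, so compound 2 cannot be placed against any second number. For the measured compounds named here, the single measured step, an at least 4.7-fold lower number from compound 1 to compound 2 (0.67 log units; beyond the scatter), is therefore read against that limit and is known only as a minimum. Compound 3, `CCNC(=O)CCCc1c[nH]c2ccc(F)cc12`, differs from compound 2 in one place: ethylcarbamoyl in place of hydroxyamino on a saturated chain carbon, three bonds along the chain from an aromatic carbon. That measured step bears on this change only indirectly. Going by the values given here, it shows what arrived together with the hydroxyamino group, and compound 3 gives that group up for one whose arrival no measured step describes. With the hydroxyamino gone, the number is expected to move back towards the limit rather than stay, and the step from compound 2 is estimated as a 19-fold higher number from compound 2 to compound 3 (1.28 log units; beyond the scatter). Compound 3 is expected to give about 400 nM in this assay, with a range from 60 nM to 3000 nM and a fair chance that only a limit is reported.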

Compound 3, half-maximal inhibitory concentration: 243 nM
The estimate for compound 3 lay 1.6-fold (0.22 log units) above the measured number; the range from low to high includes it.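

In this assay, this position now has its first step read between two actual numbers, and swapping hydroxyamino for ethylcarbamoyl on the saturated chain carbon gives a 12-fold higher number from compound 2 to compound 3 (1.06 log units; beyond the scatter). The potency of compound 2 therefore does not carry over to every group placed here: ethylcarbamoyl, with 5 heavy atoms against the 2 of hydroxyamino and one carbonyl double bond, does not hold the number of compound 2. The step from compound 1 to compound 3 cannot be read, because the value of compound 1 is a limit and not a number: the limit of > 100 nM in this assay, at which 1 of the 3 values shown sits.

This single swap changes several things at once, so the compounds shown do not tell which part of the hydroxyamino group matters, or whether the ethyl, the carbonyl or the amide hydrogen of the new group accounts for the step. A plain amine or a carboxylic acid at this place, or hydroxyamino on a longer chain, would help to separate these possibilities.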